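A Chloro Substituent on the Sulfonyl Phenyl of Compound 2

The source may hold more compounds than are shown below. What is called first, only, known or untested is meant among the compounds shown, and "the series" means these compounds.

Compound 1 `CC1=NC(c2cn(S(C)(=O)=O)c3ccccc23)CN1` gives no number in an assay on isolated protein for inhibition of kallikrein-7 (Homo sapiens), read by fluorescence, with stated times of 10 min and 30 min (a higher number here means a weaker inhibitor, a lower number a stronger inhibitor), but only the limit > 100000 nM (the limit of > 100000 nM in this assay, at which 1 of the 2 values shown sits). Compound 2 `CC1=NC(c2cn(S(=O)(=O)c3ccccc3)c3ccc(C)cc23)CN1` gives 17000 nM in this assay, the only numerical value among the two results shown. Compound 3 `CC1=NC(c2cn(S(=O)(=O)c3cccc(Cl)c3)c3ccc(C)cc23)CN1` differs from compound 2 by chloro in place of hydrogen on an aromatic carbon. Among the measured compounds shown here, no measured step of this kind exists here; the author expects a small gain in inhibition, close in size to the usual scatter. Compound 3 is therefore estimated at 8000 nM, within 2500 nM to 25000 nM. The expected step is a 2.1-fold lower number from compound 2 to compound 3 (0.33 log units; beyond the scatter).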

Compound 3, half-maximal inhibitory concentration: 30000 nM
Compound 3: middle estimate off by 3.8-fold (0.57 log units), on the low side; measured number above the stated range.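

In this assay, chloro in place of hydrogen on an aromatic carbon, meta to a large group, gives a 1.8-fold higher number from compound 2 to compound 3 (0.25 log units; within the scatter), so phenyl and 3-chlorophenyl cannot be told apart here. Among the compounds shown here, this is the first substituent read on this sulfonyl phenyl, and it yields no measurable gain or loss in inhibition. Nothing in the data shown bears on this result. From the compounds shown here alone, whether an amine, a methoxy group or a carboxylic acid at this place would give a step beyond the scatter remains open. So does the effect of chloro elsewhere on this ring.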